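Working notes on the aryl group of compound 2

A few compounds are considered here, and "the series" means these few. Any claim that something is new, unique, unknown or untested is made for them only; others in the source may bear on it.

In a functional assay on DU-145 cells (Homo sapiens) for antiproliferative activity, read by MTT assay, with a stated time of 48 h (a higher number here means a weaker inhibitor, a lower number a stronger inhibitor), compound 1 (`C/C(=C\CC/C(C)=C/CC[C@@H]1[C@@]2(C)CCC(=O)C(C)(C)[C@H]2CC[C@@]1(C)O)CC/C=C(\C)C(=O)OCc1cn(-c2cccc(Cl)c2)nn1`) gives 103000 nM. Compound 2 (`C/C(=C\CC/C(C)=C/CC[C@@H]1[C@@]2(C)CCC(=O)C(C)(C)[C@H]2CC[C@@]1(C)O)CC/C=C(\C)C(=O)OCc1cn(-c2ccc(C(C)(C)C)cc2)nn1`) gives > 150000 nM, which is a limit of the assay and not a number. Compound 2 can therefore be placed only by that limit (the limit of > 150000 nM in this assay, at which 1 of the 2 values shown sits).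

The next change leads to compound 3 (`C/C(=C\CC/C(C)=C/CC[C@@H]1[C@@]2(C)CCC(=O)C(C)(C)[C@H]2CC[C@@]1(C)O)CC/C=C(\C)C(=O)OCc1cn(-c2cccc(O)c2)nn1`), with 3-hydroxyphenyl in place of 4-(tert-butyl)phenyl on an aromatic nitrogen.

Going by the values given here, one measured step bears on this change, as it sits at the same place: an at least 1.4-fold higher number from compound 1 to compound 2 (0.16 log units; that floor lies within the scatter). Its floor lies within the scatter, so it shows no clear effect from exchanging these aryl groups. Among the compounds with values here, the data hold no measured compound with a hydroxyphenyl group. Within the data shown here, with only this step as a guide, compound 3 is expected to read near compound 1 at 103000 nM, and no clear gain in this assay is expected. The expected change is small and lies toward a lower number, no larger than the scatter: an at least 1.5-fold lower number from compound 2 to compound 3 (0.17 log units; that floor lies within the scatter). The estimate for compound 3 is 100000 nM, with an expected range of 50000 nM to 170000 nM.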

Compound 3, half-maximal inhibitory concentration: 28400 nM
For compound 3 the middle estimate is 3.5-fold (0.55 log units) above the measured one; the whole stated range lies above it.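

Going by these compounds alone, the aryl group on the aromatic nitrogen does move the read-out in this assay: hydroxy in place of chloro on an aromatic carbon gives a 3.6-fold lower number from compound 1 to compound 3 (0.56 log units; beyond the scatter), whereas the only earlier step had a floor within the scatter. Exchanging 4-(tert-butyl)phenyl for 3-hydroxyphenyl gives an at least 5.2-fold lower number from compound 2 to compound 3 (0.72 log units; beyond the scatter), so this larger change also clears the scatter, and the two steps agree in direction toward compound 3. The size of that second step is only a floor, since compound 2 is held at a limit of the assay and not at a number: the limit of > 150000 nM in this assay, at which 1 of the 3 values shown sits.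

The compounds shown leave open whether the lower number belongs to the hydroxy group itself or would also follow from another group at that ring carbon, such as a methoxy, an amine or a carboxylic acid. They also leave open how far the place of the group counts, a question that a 4-hydroxyphenyl group on the same aromatic nitrogen would address directly.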